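Swapping the amine substituent on a sulfamate amide

The source may hold more compounds than are shown below. What is called first, only, known or untested is meant among the compounds shown, and "the series" means these compounds.

Measured so far in an assay on HEK293 cells for inhibition of Steryl-sulfatase (Homo sapiens), tested at 0.1 uM; a higher number here means a stronger effect of the compound at the concentration tested, a lower number a weaker effect:
- compound 1 `NS(=O)(=O)Oc1ccc2c(c1)CN(C(=O)c1ccc(N3CCCCC3)cc1)CC2`: 11.5%
- compound 2 `CCN(Cc1ccc(F)cc1)c1ccc(C(=O)N2CCc3ccc(OS(N)(=O)=O)cc3C2)cc1`: 69.1%

Among the compounds with values here, compound 2 stands highest of the two numbers measured; its nearest neighbour is compound 1, and the only step known is a number 57.6 percentage points higher from compound 1 to compound 2 (beyond the scatter), a large one that came from exchanging the whole amine substituent on the aromatic ring.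

Compound 3 `CCCN(Cc1ccccc1)c1ccc(C(=O)N2CCc3ccc(OS(N)(=O)=O)cc3C2)cc1` has not yet been measured. It keeps the core of compound 2 and changes only the amine: benzyl(propyl)amino in place of ethyl(4-fluorobenzyl)amino on an aromatic carbon. Both the group that leaves and the group that enters are open-chain amines carrying a benzyl arm, so this step is far smaller in kind than the step from a ring amine seen before. Within the data shown here, no measured pair bears directly on it.

Compound 3 is therefore expected to stay near compound 2, with an estimated step of a number 9.1 percentage points lower from compound 2 to compound 3 (within the scatter) and an estimated value of 60%, within 35% to 85%.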

Compound 3, a percentage reported as inhibition, at one concentration (the size of the read-out at that concentration, not a potency): 64.8%
The estimate for compound 3 lay 4.8 percentage points below the measured number; the measured number falls inside the stated range.
By their numbers in this assay, from the lowest: compound 1; then compounds 3 and 2 (each within the scatter of the next).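

In this assay, the swap of ethyl(4-fluorobenzyl)amino for benzyl(propyl)amino gives a number 4.3 percentage points lower from compound 2 to compound 3 (within the scatter) and so leaves the read-out unchanged within the scatter, which shows that this position accepts more than one open-chain amine carrying a benzyl arm. The gain over the ring amine also holds for a second such group, with a number 53.3 percentage points higher from compound 1 to compound 3 (beyond the scatter) in the same assay, so the large rise no longer rests on compound 2 alone. Nothing available explains why these open-chain amines outperform piperidin-1-yl.

On these data alone, the step from compound 2 to compound 3 alters the fluorine and the chain together, so their separate contributions remain unknown; ethyl(benzyl)amino would tell them apart. As far as these compounds go, it is also open whether a ring amine carrying a benzyl arm, such as 4-benzylpiperidin-1-yl, would match the open-chain amines.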